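Moving the chlorine on the outer ring of a serine-phosphate agonist

The source may report more compounds than this note shows. Statements on the series, on what has been measured and on what is new or still open speak of the compounds shown alone.

Three compounds share a core in which a serine phosphate is linked through a propyl ester to a phenyl ether. Compound 1 `N[C@@H](COP(=O)(O)OCCCOC(=O)CCc1ccccc1OCc1cccc(Oc2ccccc2)c1)C(=O)O` reaches 0.48 in an assay on cells for activation of probable G-protein coupled receptor 34 (Mus musculus), with a stated time of 1 h; a lower number here means a smaller maximal response, a higher number a larger maximal response. Compound 2 `N[C@@H](COP(=O)(O)OCCCOC(=O)CCc1ccccc1OCc1cccc(Cc2ccccc2)c1)C(=O)O` gives 0.077, and compound 3 `N[C@@H](COP(=O)(O)OCCCOC(=O)CCc1ccccc1OCc1cccc(Oc2ccccc2Cl)c1)C(=O)O` gives 0.069, the lowest of the three, sitting within the scatter of compound 2 and far beneath compound 1. The step a number 0.41 lower from compound 1 to compound 3 (beyond the scatter) shows how much one added chlorine cost, while a number 0.0080 lower from compound 2 to compound 3 (within the scatter) shows no real difference between two unlike outer groups.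

Compound 4 `N[C@@H](COP(=O)(O)OCCCOC(=O)CCc1ccccc1OCc1cccc(Oc2cccc(Cl)c2)c1)C(=O)O` keeps every atom of compound 3 but joins them differently: 3-chlorophenyl in place of 2-chlorophenyl on an oxygen on an aromatic ring. Among the compounds with values here, no measured step tests where the chlorine sits, so only a partial recovery toward compound 1 is guessed. The expected step is a number 0.081 higher from compound 3 to compound 4 (within the scatter); compound 4 is estimated at 0.15, between 0.05 and 0.4.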

Compound 4, intrinsic activity: the largest response reached, as a fraction of the reference agonist's: 0.53
For compound 4 the middle estimate is 0.38 below the measured one, and the stated range ends below it.
By their numbers in this assay, from the lowest: compounds 3 and 2 (each within the scatter of the next); then compounds 1 and 4 (each within the scatter of the next).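

Where the chlorine sits decides the outcome in this assay: 3-chlorophenyl in place of 2-chlorophenyl gives (a number 0.46 higher from compound 3 to compound 4 (beyond the scatter)), so the loss seen with compound 3 does not come with chlorine wherever it stands. With 3-chlorophenoxy the response matches that of plain phenoxy (a number 0.050 higher from compound 1 to compound 4 (within the scatter)), and 3-chlorophenoxy in place of benzyl gives (a number 0.45 higher from compound 2 to compound 4 (beyond the scatter)). Nothing available explains why the two chlorine placements differ.

Still open, from the compounds shown here alone, is how 4-chlorophenyl on the same oxygen would behave, and whether 3-methoxyphenyl or 3-aminophenyl there would match 3-chlorophenyl.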